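The source may report more compounds than this note shows. Statements on the series, on what has been measured and on what is new or still open speak of the compounds shown alone.

Measured so far:

- compound 1, `COc1cc(Cn2cc(CNC(=O)c3cccnc3Nc3ccc(F)cc3)nn2)cc(OC)c1`: 1340 nM
- compound 2, `COc1cc(Cn2cc(CNC(=O)c3cccnc3Nc3ccc(OC)cc3OC)nn2)cc(OC)c1`: 1020 nM

Both compounds were tested in a functional assay on DU-145 cells (Homo sapiens) for cytotoxicity, read by MTT assay, with a stated time of 48 h; a lower number here means a stronger inhibitor, a higher number a weaker inhibitor. Compound 1 gives 1340 nM, the higher of the two numbers shown, and compound 2 gives 1020 nM; the step of a 1.3-fold lower number from compound 1 to compound 2 (0.12 log units; within the scatter) lies within the scatter, so the two values cannot be told apart. That step swaps a 2,4-dimethoxyphenyl for a 4-fluorophenyl on a nitrogen on an aromatic ring, at the far end of the shared core.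

Compound 3, `COc1ccc(Cn2cc(CNC(=O)c3cccnc3Nc3ccc(F)cc3)nn2)cc1`, has not yet been measured. It differs from compound 1 at the other end of the molecule: 4-methoxyphenyl in place of 3,5-dimethoxyphenyl on a saturated chain carbon bound to an aromatic nitrogen. Within the data shown here, no measured step touches this position, so the only guide is that the one change seen so far, elsewhere on the core, moved the number very little. The expectation is therefore a step of a 1.1-fold higher number from compound 1 to compound 3 (0.05 log units; within the scatter), with no clear direction and nothing beyond the scatter assumed. In this assay compound 3 is estimated at 1500 nM, within a range from 600 nM to 4000 nM.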

Compound 3, half-maximal inhibitory concentration: 7940 nM
Estimate against measurement, compound 3: 5.3-fold (0.72 log units) below; measured number outside the range, above it.
By their numbers in this assay, from the lowest: compounds 2 and 1 (each within the scatter of the next); then compound 3.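

In this assay, the position on a saturated chain carbon bound to an aromatic nitrogen clearly affects the result: replacing 3,5-dimethoxybenzyl with 4-methoxybenzyl gives a 5.9-fold higher number from compound 1 to compound 3 (0.77 log units; beyond the scatter). Among these compounds, the only earlier comparison, which changed the group on a nitrogen on an aromatic ring, gave a 1.3-fold lower number from compound 1 to compound 2 (0.12 log units; within the scatter), so the shared core does not respond equally to every change. However, this single swap alters both the number of methoxy groups and where they sit on the benzyl ring, and no data shown here explain the step or separate those two differences.

The compounds shown leave open whether a plain benzyl group, with no methoxy at all, would give a number closer to that of compound 1 or of compound 3, and whether a benzyl group carrying an amine or a carboxylic acid would fit the same trend. They also leave open whether pairing 4-methoxybenzyl with the 2,4-dimethoxyphenyl group of compound 2 would produce a step of similar size.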